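Working notes: from compound 3 to compound 4

The source may hold more compounds than are shown below. What is called first, only, known or untested is meant among the compounds shown, and "the series" means these compounds.

Measured in an ADME assay on the whole organism (Mus musculus, strain BALB/c) for pharmacokinetics, read by LC-MS, with a stated time of 24 h, at a dose of 10 mg/kg by the oral route (a lower number here means less compound in the circulation, a higher number more compound in the circulation at the dose given), for the series
- compound 1 `O=S(=O)(Nc1ncccn1)c1ccc2c(c1)OCC[C@@H]2c1ccc(C(F)(F)F)cc1-c1ccc(F)nc1` - 17000 nM
- compound 2 `Cn1nccc1-c1cc(C(F)(F)F)ccc1[C@H]1CCOc2cc(S(=O)(=O)Nc3nccs3)ccc21` - 6000 nM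
- compound 3 `O=S(=O)(Nc1nccs1)c1ccc2c(c1)OCC[C@@H]2c1ccc(C(F)(F)F)cc1-n1ccnn1` - 3000 nM

Compound 3 (3000 nM) lies within the scatter of compound 2 and beyond the scatter under compound 1. Next is compound 4 `O=S(=O)(Nc1nccs1)c1ccc2c(c1)OCC[C@@H]2c1ccc(C(F)(F)F)cc1-c1ccc(F)nc1` with the change 6-fluoropyridin-3-yl in place of 1H-1,2,3-triazol-1-yl on an aromatic carbon (6-fluoropyridin-3-yl in place of 1H-1,2,3-triazol-1-yl, ortho to a large group and meta to a trifluoromethyl group). Among the measured compounds shown here, the only measured step at this place is a 2.0-fold lower number from compound 2 to compound 3 (0.30 log units; within the scatter) and it stays within the scatter. Compound 1 (17000 nM) carries the same 6-fluoropyridin-3-yl group but differs from compound 4 elsewhere, so it is only a loose guide. The expected step is a 2.7-fold higher number from compound 3 to compound 4 (0.43 log units; beyond the scatter) and points to a higher number. For compound 4 the estimated value is 8000 nM with an expected range from 3000 nM to 20000 nM in this assay here.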

Compound 4, maximal plasma concentration: 4200 nM
Compound 4: the middle estimate sits 1.9-fold (0.28 log units) above what was measured, and the stated range covers the measured number.
By their numbers in this assay, from the lowest: compounds 3, 4 and 2 (each within the scatter of the next); then compound 1.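

In this assay, 6-fluoropyridin-3-yl does not separate from the two five-membered groups at this aromatic carbon (a 1.4-fold higher number from compound 3 to compound 4 (0.15 log units; within the scatter); a 1.4-fold lower number from compound 2 to compound 4 (0.15 log units; within the scatter)). With 6-fluoropyridin-3-yl held fixed, 1,3-thiazol-2-yl in place of pyrimidin-2-yl on the sulfonamide nitrogen gives the step beyond the scatter (a 4.0-fold lower number from compound 1 to compound 4 (0.61 log units; beyond the scatter)). No measurement at hand accounts for either result.

Going by these compounds, whether an amine or a carboxylic acid on this aromatic carbon would move the number beyond the scatter remains open. Also open, on these data alone, is whether the sulfonamide step holds with 1H-1,2,3-triazol-1-yl or 1-methyl-1H-pyrazol-5-yl in place.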